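The compounds below may be only part of what the source reports. "The series", "measured", "known", "first", "only" and "open" are said of these compounds alone.

Of the compounds shown here, three of one shared core have been measured. Compound 1 `COc1ccc(/C=C/C(=O)c2ccc(O)c3c2OC(C)(C)C3)cc1` carries a free hydroxyl on the core and a methoxy on the outer ring; in a functional assay on PC-3 cells (Homo sapiens) for antiproliferative activity, read by MTT assay, with a stated time of 48 h (on this read-out higher numbers stand for weaker inhibition and lower numbers for stronger inhibition), compound 1 gives 48400 nM. Compound 2 `CC1(C)Cc2c(ccc(C(=O)/C=C/c3ccccc3)c2OCc2ccccc2)O1` instead carries a benzyl ether on the core and a plain outer ring. In this assay compound 2 reaches only the limit of > 100000 nM, which is a limit of the assay and not a number. Compound 3 `CC1(C)Cc2c(ccc(C(=O)/C=C/c3ccc(Cl)cc3)c2OCc2ccccc2)O1` adds a chloro to the outer ring of compound 2. In this assay compound 3 also gives only the limit of > 100000 nM. The step that the two limits leave unreadable from compound 2 to compound 3 therefore cannot be sized. Compound 3 thus stands at the limit of > 100000 nM in this assay, at which 2 of the 3 values shown sit, and no number is known for it.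

Compound 4 `CC1(C)Cc2c(ccc(C(=O)/C=C/c3ccc(Br)cc3)c2OCc2ccccc2)O1` differs from compound 3 only in bromo in place of chloro on an aromatic carbon. No measured step bears on this exchange, and the only step shown is itself unreadable, so no direction can be given. Compound 4 is expected to remain near the limit, an estimated step of a number no higher from compound 3 to compound 4 (the limit leaves the size open), giving an expected value of about 100000 nM, between 40000 nM and 250000 nM.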

Compound 4, half-maximal inhibitory concentration: > 50000 nM
Compound 4: only a limit was reported; the forecaster's own chance of this, stated with the estimate: 70%; the middle value lies beyond the limit too.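

Compound 4 gives > 50000 nM, which is a limit and not a number. Compound 2 and compound 3 also stand only at limits, so neither step to compound 4 can be read. Going by these compounds, whether hydrogen, chloro or bromo on the outer ring makes any difference stays open.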